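The compounds below may be only part of what the source reports. "The series", "measured", "known", "first", "only" and "open" are said of these compounds alone.

For the measured compounds named here, in a functional assay on K562 cells (Homo sapiens) for cytotoxicity, read by MTT assay (a lower number here means a stronger inhibitor, a higher number a weaker inhibitor), compound 1 (`CCCCC(=O)Oc1cc(/C=C/C(=O)c2ccc(OC)c3c2OC(C)(C)C=C3)ccc1OC`) gives 240 nM, and its only measured neighbour, compound 2 (`COc1ccc(/C=C/C(=O)Oc2cc(/C=C/C(=O)c3ccc(OC)c4c3OC(C)(C)C=C4)ccc2OC)cc1`), gives 380 nM. These two numbers lie within the scatter of each other, so compound 1 holds no clear place in the series. Compound 3 (`COc1ccc(/C=C/C(=O)c2ccc(OC)c3c2OC(C)(C)C=C3)cc1CS(C)(=O)=O`) has (methylsulfonyl)methyl in place of (butylcarbonyl)oxy on an aromatic carbon, ortho to a methoxy group: (methylsulfonyl)methyl in place of (butylcarbonyl)oxy on an aromatic carbon. Going by the values given here, the one measured step that bears on this, a 1.6-fold higher number from compound 1 to compound 2 (0.20 log units; within the scatter), put 2-(4-methoxyphenyl)ethenyl in place of butyl on a carbonyl carbon. That step stayed small, but it left the rest of the (butylcarbonyl)oxy group in place, so it only weakly guides the full replacement. No step beyond the scatter is therefore expected in this assay, and no direction can be firmly expected. The estimated step is a 1.5-fold higher number from compound 1 to compound 3 (0.16 log units; within the scatter). For compound 3 the expected value is 350 nM, with an estimated range of 100 nM to 1500 nM.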

Compound 3, half-maximal inhibitory concentration: 9240 nM
Compound 3: middle estimate off by 26-fold (1.42 log units), on the low side; measured number outside the range, above it.
By their numbers in this assay, from the lowest: compounds 1 and 2 (each within the scatter of the next); then compound 3.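

In this assay this aromatic carbon, ortho to a methoxy group, proves sensitive to the replacement of the whole group: (methylsulfonyl)methyl in place of (butylcarbonyl)oxy gives a 39-fold higher number from compound 1 to compound 3 (1.59 log units; beyond the scatter). The earlier step, a 1.6-fold higher number from compound 1 to compound 2 (0.20 log units; within the scatter), changed only what sits on the carbonyl carbon and kept the rest of the (butylcarbonyl)oxy group, so the latitude seen there does not extend to exchanging the group entire. The two groups have the same count of hydrogen-bond acceptors and no donors, and nothing measured here accounts for the step.

The change swaps the whole group at once, and the compounds shown do not separate the part played by the oxygen on the ring from that of the sulfonyl. On these data alone, how a hydroxyl, an amine or a longer ester chain on this carbon would read in this assay also remains open.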